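The source may hold more compounds than are shown below. What is called first, only, known or untested is meant among the compounds shown, and "the series" means these compounds.

Measured compounds:
Compound 1 `O=C(NC[C@@H]1C[C@@H]2C=C[C@@H]1C2)NS(=O)(=O)N1CCC(CCNC(=O)c2cscn2)CC1`: 37%
Compound 2 `CSc1ccc(C(F)(F)F)cc1C(=O)NCCC1CCN(S(=O)(=O)NC(=O)NC2CCCCC2)CC1`: 24%
Compound 3 `O=C(NC1CCCCC1)NS(=O)(=O)N1CCC(CCNC(=O)c2nsc3ccccc23)CC1`: 17%

All three were tested in a functional assay on the whole organism (blood) with Rattus norvegicus as the target, with stated times of 24 h and 1 h, at a dose of 15 mg/kg by the intraperitoneal route; on this read-out lower numbers stand for a weaker effect and higher numbers for a stronger effect at the one dose given. Compound 1 gives the highest of the three numbers, and its gaps to compound 2 and to compound 3 both lie beyond the usual scatter, so compound 1 stands clearly at the top of this small set.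

Compound 4 `O=C(NC[C@@H]1C[C@@H]2C=C[C@@H]1C2)NS(=O)(=O)N1CCC(CCNC(=O)c2nc3ccccc3s2)CC1` is the next compound to be measured. It differs from compound 1 in one place: 1,3-benzothiazol-2-yl in place of 1,3-thiazol-4-yl on a carbonyl carbon. So a five-membered aromatic ring with 2 hetero atoms is replaced by a fused system that adds a six-membered aromatic ring of carbon only, on the carbonyl carbon of the amide.

Within the data shown here, one measured step bears on this. From compound 2 to compound 3 a bicyclic group containing a five-membered aromatic ring with 2 hetero atoms also entered on a carbonyl carbon, and the result was a number 7 percentage points lower from compound 2 to compound 3 (within the scatter), within the scatter. That step started from a different group and a different core, so it is only a loose guide. Compound 3, which carries a bicyclic group, also shows the lowest number of the three, though it differs from compound 1 in more than one place.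

The expectation for compound 4 is therefore a small change, if any, in this assay, a number 5 percentage points lower from compound 1 to compound 4 (within the scatter), not clearly beyond the scatter. Compound 4 is estimated at 32%, with a likely range from 18% to 46%.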

Compound 4, a percentage reported as activity, at one dose (the size of the read-out at that dose, not a potency): 34%
Estimate against measurement, compound 4: 2 percentage points below; the range from low to high includes it.
By their numbers in this assay, from the lowest: compounds 3, 2, 4 and 1 (each within the scatter of the next, the first and the last beyond it).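

On the carbonyl carbon of the amide, with the rest of compound 1 kept the same, placing 1,3-benzothiazol-2-yl in place of 1,3-thiazol-4-yl gives, in this assay, a number 3 percentage points lower from compound 1 to compound 4 (within the scatter). Among these compounds, this is the first comparison in the set in which only this group changes, and it shows that going from 5 to 9 heavy atoms, by adding a six-membered aromatic ring of carbon only, does not separate the two compounds at this one dose. Nothing available here explains why the two groups read alike.

The pair leaves open whether the fused ring or the change in how the group is attached matters more on a different scale, and 1,3-thiazol-2-yl on the same carbonyl carbon would help to tell those two apart. It also leaves open how far this position tolerates change, since a pyridin-2-yl group, or a 1,3-thiazol-4-yl group carrying an amine or a carboxylic acid, could read quite differently from the two groups compared here.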